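Removing the Hydroxy from Compound 2

The source may hold more compounds than are shown below. What is called first, only, known or untested is meant among the compounds shown, and "the series" means these compounds.

Measured in a functional assay for inhibition, with Homo sapiens as the target; on this read-out higher numbers stand for weaker inhibition and lower numbers for stronger inhibition:
Compound 1 `Cc1cc2c(cc1C(=O)N=C(N)N)S(=O)(=O)CC2C(C)C`: 77 nM
Compound 2 `CCC1(O)CS(=O)(=O)c2cc(C(=O)N=C(N)N)c(C)cc21`: 77 nM
Compound 3 `Cc1cc2c(cc1C(=O)N=C(N)N)S(=O)(=O)CC2(O)C(=O)c1ccccc1`: 157 nM

Compound 2 sits level with compound 1, and together they hold the lowest of the three numbers. The next change leads to compound 4 `CCC1CS(=O)(=O)c2cc(C(=O)N=C(N)N)c(C)cc21`, with hydrogen in place of hydroxy on a saturated ring carbon. Going by the values given here, only one measured step bears on this, also on a saturated ring carbon: a 2.0-fold higher number from compound 2 to compound 3 (0.31 log units; beyond the scatter), a modest change. That step replaces ethyl with benzoyl and keeps the hydroxy, so no measurement shows the loss of the hydroxy directly. In this assay, as far as these compounds go, no step beyond the scatter is therefore expected, and the direction stays open. The estimated change is a 1.1-fold lower number from compound 2 to compound 4 (0.04 log units; within the scatter). For compound 4 the expected value is 70 nM, with an estimated range from 30 nM to 170 nM.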

Compound 4, half-maximal inhibitory concentration: 78 nM
For compound 4 the middle estimate is 1.1-fold (0.05 log units) below the measured one; low and high end bracket the measured number.
By their numbers in this assay, from the lowest: compounds 1, 2, 4 and 3 (each within the scatter of the next, the first and the last beyond it).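

In this assay, the hydroxy on this saturated ring carbon proves dispensable, since hydrogen in its place leaves the number within the scatter (a 1.0-fold higher number from compound 2 to compound 4 (0.01 log units; within the scatter)). Hydrogen in place of methyl on the saturated chain carbon also stays within the scatter (a 1.0-fold higher number from compound 1 to compound 4 (0.01 log units; within the scatter)), so compound 4 with its ethyl matches both neighbours. No measurement shown gives a reason for either result.

The compounds shown leave open how an amine or a carboxylic acid would read on this ring carbon. As far as these compounds go, a longer chain at this position also remains untested here.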